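The compounds below may be only part of what the source reports. "The series", "measured", "known", "first", "only" and "open" are said of these compounds alone.

In a functional assay on L5178Y cells (Mus musculus) for inhibition, read by MTT assay, with a stated time of 24 h (a lower number here means a stronger inhibitor, a higher number a weaker inhibitor), compound 1 (`COc1cc(O)c2c(c1)O[C@H](c1ccc(OCC(O)CCl)cc1)CC2=O`) gives >= 11300 nM as a limit and not a number. Compound 2 (`CCN(CC)CC(O)COc1ccc([C@@H]2CC(=O)c3c(O)cc(OC)cc3O2)cc1`) likewise gives only a limit, >= 11300 nM, so its standing is bounded but not fixed. Within the data shown here, the one measured step is a step that the two limits leave unreadable from compound 1 to compound 2 and offers no size to carry forward, and both compounds sit together at the limit of >= 11300 nM in this assay, at which 2 of the 2 values shown sit. Compound 3 (`COc1cc(O)c2c(c1)O[C@H](c1ccc(OCC(O)CN3CCCCC3)cc1)CC2=O`) differs from compound 2 by piperidin-1-yl in place of diethylamino on a saturated chain carbon, two bonds along the chain from an oxygen on a saturated carbon, with piperidin-1-yl in place of diethylamino. No change beyond the scatter is expected, and the estimated step is a step that the limit leaves unreadable from compound 2 to compound 3. For compound 3 the expected value is 12000 nM, within an estimated range of 5000 nM to 30000 nM.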

Compound 3, half-maximal inhibitory concentration: 9300 nM
Beside the measured number, compound 3's estimate is 1.3-fold (0.11 log units) above it; the measured number falls inside the stated range.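

In this assay compound 3, alone among the three, gives a number and not a limit, 9300 nM, with piperidin-1-yl on the saturated chain carbon. The data give an at least 1.2-fold lower number from compound 2 to compound 3 (0.08 log units; that floor lies within the scatter) and an at least 1.2-fold lower number from compound 1 to compound 3 (0.08 log units; that floor lies within the scatter), so no real gain over either compound is established. The values of compound 1 and compound 2 remain limits and not numbers: the limit of >= 11300 nM in this assay, at which 2 of the 3 values shown sit.

Going by these compounds, how large either step really is stays open. So does whether pyrrolidin-1-yl, morpholin-4-yl or a longer chain carrying piperidin-1-yl would give a lower number.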